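Cyclobutylcarbonyl in place of acetyl on a thiadiazoline core

A few compounds are considered here, and "the series" means these few. Any claim that something is new, unique, unknown or untested is made for them only; others in the source may bear on it.

Measured so far:
- compound 1, `CC1(C)SC(c2cc(Cl)ccc2N)=NN1C(=O)C1CCC1`: -4.65%
- compound 2, `CC(=O)N1N=C(c2ccccc2N)SC1(C)C`: 22.9%

Both compounds were tested in an assay on isolated protein for inhibition of Nitric oxide synthase, inducible (Homo sapiens), read by scintillation counting, with a stated time of 30 min, tested at 50 uM; a lower number here means less inhibition, a higher number more inhibition at the concentration tested (going by the name of the read-out). Compound 2, `CC(=O)N1N=C(c2ccccc2N)SC1(C)C`, stands highest of the two numbers; its nearest neighbour is compound 1, whose value lies lower by a gap beyond the usual scatter. Compound 1 also carries a chlorine on the aromatic ring that compound 2 lacks, so those two values alone do not separate the effect of the acyl group from that of the chlorine.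

Compound 3, `CC1(C)SC(c2ccccc2N)=NN1C(=O)C1CCC1`, has not been measured. It differs from compound 2 in one place: cyclobutyl in place of methyl on a carbonyl carbon. Going by the values given here, no step between two measured compounds shows this change on its own. Among the compounds with values here, the two values above give some grounds for caution, since the only compound bearing the cyclobutylcarbonyl group, compound 1, shows the lower number, though with a second difference in play. The step of a number 10.9 percentage points lower from compound 2 to compound 3 (beyond the scatter) is therefore expected to be small to moderate downward, possibly within the scatter. Compound 3 is expected to give 12%, within a range of -8% to 30%.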

Compound 3, a percentage reported as inhibition, at one concentration (the size of the read-out at that concentration, not a potency): 46.9%
Compound 3: middle estimate off by 34.9 percentage points, on the low side, and the stated range ends below it.
By their numbers in this assay, from the lowest: compound 1; then compound 2; then compound 3.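

Changing the acyl group on the amide-type ring nitrogen from acetyl to cyclobutylcarbonyl gives a number 24 percentage points higher from compound 2 to compound 3 (beyond the scatter) in this assay, so this position accepts the larger ring, and the cyclobutylcarbonyl group does not by itself bring the number down. With that acyl group held fixed, hydrogen in place of chloro on the aromatic ring gives a number 51.6 percentage points higher from compound 1 to compound 3 (beyond the scatter) and so separates the two differences that the earlier pair left tangled. Nothing available accounts for either step.

From the compounds shown here alone, whether the rise continues with other acyl groups, such as cyclopropylcarbonyl, benzoyl or a longer chain like pentanoyl, remains open. So does whether chloro on the aromatic ring has the same effect alongside acetyl, or how a fluoro or methoxy group there would compare.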